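The source may hold more compounds than are shown below. What is called first, only, known or untested is meant among the compounds shown, and "the series" means these compounds.

Of the compounds shown here, two built on a shared core have been measured in an assay on cells for inhibition of MAP kinase-interacting serine/threonine-protein kinase 1 (Homo sapiens), read by mobility shift assay, with stated times of 10 min and 60 min, in the presence of a further agent that is not named here; on this read-out higher numbers stand for weaker inhibition and lower numbers for stronger inhibition. Compound 1 `CNC(=O)c1cncc(-c2ccc(C(N)=O)c(OC(C)C)c2)c1` gives 1900 nM there. Compound 2 `NCCOc1cc(-c2cccnc2)ccc1C(N)=O` gives 820 nM in this assay, the lower of the two numbers, and the gap to compound 1 lies beyond the scatter, so compound 2 stands as the stronger inhibitor of the pair. Compound 3 `COc1cc(-c2cccnc2)ccc1C(N)=O` has not yet been measured. It differs from compound 2 in a single place: hydrogen in place of aminomethyl on a saturated chain carbon bound to an oxygen on an aromatic ring. Cut one bond further out, the change reads 2-aminoethoxy to methoxy. For the measured compounds named here, no measured pair shows this change, so its effect is unknown from the data at hand. The step of a 2.0-fold higher number from compound 2 to compound 3 (0.29 log units; within the scatter) is expected to be a modest rise in the number, toward weaker inhibition, of a size that may only just exceed the scatter. For compound 3 the value in this assay is accordingly estimated at 1600 nM, within a range from 500 nM to 5000 nM.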

Compound 3, half-maximal inhibitory concentration: 2800 nM
Estimate against measurement, compound 3: 1.8-fold (0.24 log units) below; measured number inside the range.
By their numbers in this assay, from the lowest: compound 2; then compounds 1 and 3 (each within the scatter of the next).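

In this assay, the change from 2-aminoethoxy to methoxy now has a measured size: a 3.4-fold higher number from compound 2 to compound 3 (0.53 log units; beyond the scatter), a step beyond the scatter toward weaker inhibition. For the compounds shown here, this is the first reading of any change at this place, on a saturated chain carbon bound to an oxygen on an aromatic ring, and it shows that the number responds to what sits there, being lower with aminomethyl than with hydrogen. Nothing at hand offers an explanation for this step.

The step removes one carbon and one nitrogen together, so it leaves open whether an ethoxy or a 2-hydroxyethoxy group would give a number nearer that of compound 2 or that of compound 3. Also open, from the compounds shown here alone, is how a longer chain such as 3-aminopropoxy, or a 2-(dimethylamino)ethoxy group, would read at this place.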